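Three glycosyl amides and a shortened alkyl group

The source may hold more compounds than are shown below. What is called first, only, known or untested is meant among the compounds shown, and "the series" means these compounds.

The series rests on a shared sugar-amide core. Compound 1, `CC(C)c1ccc(/C=C/C(=O)N[C@@H]2O[C@H](CO)[C@@H](O)[C@H](O)[C@H]2O)cc1`, carries an isopropyl group on its aromatic ring and gives 0.296 in a physicochemical assay for lipophilicity, measured as octanol-water partition; a higher number here means a more lipophilic compound, a lower number a more polar compound. Compound 3, `C[C@@H](Cc1ccc(C(C)(C)C)cc1)C(=O)N[C@@H]1O[C@H](CO)[C@@H](O)[C@H](O)[C@H]1O`, gives 0.379 in this assay, and compound 2, `O=C(C[C@H](c1ccc(Cl)cc1)C1CC1)N[C@@H]1O[C@H](CO)[C@@H](O)[C@H](O)[C@H]1O`, gives 0.083. The gaps between compound 1 and each of these two lie within the scatter of repeated measurements, so the three numbers are best read as sitting close together rather than in any order.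

The unmeasured compound 4, `CCc1ccc(/C=C/C(=O)N[C@@H]2O[C@H](CO)[C@@H](O)[C@H](O)[C@H]2O)cc1`, differs from compound 1 by a single counted change: hydrogen in place of methyl on a saturated chain carbon bound to an aromatic carbon and a saturated chain carbon. Read one bond further out, this is isopropyl to ethyl, the removal of one carbon with no change in ring count, hydrogen-bond donors, hydrogen-bond acceptors or charge.

Among the measured compounds shown here, no measured pair within the set shows this kind of step, so its size must be estimated from the change alone. He expects the loss of one carbon to lower the partition coefficient modestly, by an amount around the edge of the scatter, giving the step of a number 0.40 log units lower from compound 1 to compound 4 (beyond the scatter). Compound 4 is therefore estimated at -0.1, with a range from -0.5 to 0.3.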

Compound 4, partition coefficient: 0.04
Estimate against measurement, compound 4: 0.14 log units below, within the range that was stated.
By their numbers in this assay, from the lowest: compounds 4, 2, 1 and 3 (each within the scatter of the next, the first and the last beyond it).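

In this assay, the change from isopropyl to ethyl, hydrogen in place of methyl on a saturated chain carbon bound to an aromatic carbon and a saturated chain carbon, is a number 0.26 log units lower from compound 1 to compound 4 (within the scatter). Among the compounds shown here, this is the first step that isolates a single change, and it shows that taking out this one carbon, with the rest of the structure held fixed, does not separate the two compounds beyond the scatter. Nothing further on record bears on this step, so it stands as a bare measurement.

On these data alone, whether a longer chain, an amine or a carboxylic acid at this same place on the aromatic ring of compound 1 would give a step beyond the scatter remains open. Also open, as far as these compounds go, is whether the same exchange of isopropyl for ethyl would give a step of similar size in a compound with a different link between the aromatic ring and the amide, such as those of compound 2 and compound 3.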